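A few compounds are considered here, and "the series" means these few. Any claim that something is new, unique, unknown or untested is made for them only; others in the source may bear on it.

Working notes on the series. Compound 1 `COc1ccc(CNc2nc([SeH])nc3ccccc23)cc1` gives in an ADME assay on 184B5 cells (Homo sapiens) for cytotoxicity, read by MTT assay, with a stated time of 72 h (a higher number here means a weaker inhibitor of growth, a lower number a stronger inhibitor of growth), only a limit, > 100000 nM, and no number; this is the limit of > 100000 nM in this assay, at which 1 of the 3 values shown sits. The numbers in this assay are held by compound 2 `CSc1ccc(CNc2nc([SeH])nc3ccccc23)cc1`, at 86300 nM, and compound 3 `[SeH]c1nc(NCc2ccccc2)c2ccccc2n1`, at 63600 nM. The steps among these three change the group on the benzyl ring: an at least 1.1-fold lower number from compound 1 to compound 2 (0.06 log units; that floor lies within the scatter), an at least 1.5-fold lower number from compound 1 to compound 3 (0.19 log units; that floor lies within the scatter), and a 1.4-fold lower number from compound 2 to compound 3 (0.13 log units; within the scatter). Compound 4 `COc1ccc(CNc2nc(S)nc3ccccc23)cc1` differs from compound 1 in another place: one sulfur atom in place of one selenium atom, on an aromatic carbon. Going by the values given here, no measured step covers an exchange of this kind, and the three steps recorded all stay within the scatter, so in this assay no step beyond the scatter is expected from compound 1 to compound 4, a number no higher from compound 1 to compound 4 (the limit leaves the size open). Compound 4 is estimated at 100000 nM, within 45000 nM to 220000 nM.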

Compound 4, concentration for total growth inhibition: 36600 nM
Beside the measured number, compound 4's estimate is 2.7-fold (0.44 log units) above it; measured number below the stated range.
By their numbers in this assay, from the lowest: compounds 4, 3 and 2 (each within the scatter of the next, the first and the last beyond it). At a limit, above all of these: compound 1.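

In this assay, going by these compounds alone, sulfur in place of selenium on the aromatic carbon between two ring nitrogen atoms gives the first step beyond the scatter: an at least 2.7-fold lower number from compound 1 to compound 4 (0.43 log units; beyond the scatter). The earlier steps shown here, all on the benzyl ring, stayed within the scatter, so this position shows a change that they did not. The size of the step remains a floor, because compound 1 stands at a limit: the limit of > 100000 nM in this assay, at which 1 of the 4 values shown sits.

As far as these compounds go, whether the same exchange gives a similar step with hydrogen or methylsulfanyl on the benzyl ring remains open. Also open, from the compounds shown here alone, is what an amine or a methyl group would give between the two ring nitrogen atoms.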